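Benzyl to 4-fluorophenyl on the aromatic nitrogen

This account rests on a few compounds, and the source may have more. Where it says the series, first, only, none or still open, it means among the compounds named here.

In a functional assay on HT-29 cells (Homo sapiens) for antiproliferative activity, read by MTT assay, with a stated time of 72 h (on this read-out higher numbers stand for weaker inhibition and lower numbers for stronger inhibition), compound 1 (`CCCCn1ccnc1-c1cc(OC)c(OC)c(OC)c1`) gives > 100000 nM as a limit. Compound 2 (`COc1cc(-c2nccn2Cc2ccccc2)cc(OC)c1OC`) gives > 100000 nM as a limit too. Compound 2 therefore has no number, only the limit shared by both compounds (the limit of > 100000 nM in this assay, at which 2 of the 2 values shown sit). The change 4-fluorophenyl in place of benzyl on an aromatic nitrogen gives compound 3 (`COc1cc(-c2nccn2-c2ccc(F)cc2)cc(OC)c1OC`) its 4-fluorophenyl in place of benzyl on an aromatic nitrogen. For the measured compounds named here, the one measured step that the two limits leave unreadable from compound 1 to compound 2 has no readable size and sets no scale here. The expected step is an at least 5.0-fold lower number from compound 2 to compound 3 (0.69 log units; beyond the scatter) toward stronger inhibition, on weak grounds. For compound 3 the estimated value is 20000 nM with an expected range from 1000 nM to 100000 nM and a real chance of another limit.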

Compound 3, half-maximal inhibitory concentration: 29300 nM
Compound 3: middle estimate off by 1.5-fold (0.17 log units), on the low side, within the range that was stated.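

In this assay, 4-fluorophenyl on the aromatic nitrogen gives a readable number where benzyl and butyl give none, with an at least 3.4-fold lower number from compound 2 to compound 3 (0.53 log units; beyond the scatter) and an at least 3.4-fold lower number from compound 1 to compound 3 (0.53 log units; beyond the scatter). The step between compound 1 and compound 2 cannot be read, and the two steps to compound 3 give minimum sizes only, because compound 1 and compound 2 both sit at a limit: the limit of > 100000 nM in this assay, at which 2 of the 3 values shown sit.

Still open, going by these compounds, is whether the step follows the ring bound directly to the nitrogen or the fluorine on that ring. Plain phenyl or a chlorophenyl on the same nitrogen would separate the two.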